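The source may hold more compounds than are shown below. What is called first, only, known or untested is meant among the compounds shown, and "the series" means these compounds.

Measured so far:
- compound 1, `Nc1ccccc1NC(=O)c1ccc(COc2ccc(Br)cc2)cc1`: 24400 nM
- compound 2, `CC(C)c1ccc(OCc2ccc(C(=O)Nc3ccccc3N)cc2)cc1`: 7460 nM

Both numbers come from a functional assay on A549 cells (Homo sapiens) for antiproliferative activity, read by CCK-8 assay, with a stated time of 72 h; a lower number here means a stronger inhibitor, a higher number a weaker inhibitor. Among the measured compounds shown here, compound 2 holds the lower of the two numbers measured; the only neighbour is compound 1, which sits higher by the one step recorded, a 3.3-fold lower number from compound 1 to compound 2 (0.51 log units; beyond the scatter).

The next compound, compound 3, is `Nc1ccccc1NC(=O)c1ccc(COc2ccc([N+](=O)[O-])cc2)cc1`. Its difference from compound 2 is nitro in place of isopropyl on an aromatic carbon. For the measured compounds named here, the replaced isopropyl is exactly the group that compound 2 gained from compound 1, so the single recorded step is the only one that bears on this change, and it bears only indirectly: it shows that the bromo-to-isopropyl swap moved the number by a 3.3-fold lower number from compound 1 to compound 2 (0.51 log units; beyond the scatter), but nothing measured here contains a nitro group. Going by the values given here, no step from isopropyl to nitro exists.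

The working expectation for compound 3 is therefore cautious: a step of about a 2.0-fold higher number from compound 2 to compound 3 (0.30 log units; within the scatter) in this assay, returning toward the number of compound 1 rather than moving further below compound 2. Compound 3 is estimated at 15000 nM, with a range from 5000 nM to 45000 nM.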

Compound 3, half-maximal inhibitory concentration: > 32000 nM
Compound 3: a limit, no number (the forecaster's own chance of this, stated with the estimate: 10%); middle value at least 2.1-fold (0.32 log units) from the limit.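

In this assay compound 3 gives > 32000 nM, which is a limit of the assay and not a number. The aromatic carbon para to a large group now has a second recorded change, and replacing isopropyl with nitro gives an at least 4.2-fold higher number from compound 2 to compound 3 (0.63 log units; beyond the scatter), so the number at this position moves upward as well as downward with the group placed there. Against bromo, the same position gives an at least 1.3-fold higher number from compound 1 to compound 3 (0.11 log units; that floor lies within the scatter), so the order of compound 1 and compound 3 stays unsettled, while compound 2 holds the lowest number of the three, with its steps to both others beyond the scatter.

The limit leaves the true size of both steps involving compound 3 open, and three groups at one position give no basis for a trend or a cause. As far as these compounds go, whether the lower number of compound 2 is particular to isopropyl or extends to a tert-butyl group or a longer alkyl chain remains open, as does the effect of an amine or a carboxylic acid at the same position.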